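The source may hold more compounds than are shown below. What is called first, only, known or untested is meant among the compounds shown, and "the series" means these compounds.

Compound 2 `CCCc1nc(CC)c(C(=O)OCc2ccccc2OC)n1Cc1ccc(-c2ccccc2S(=O)(=O)NC(=O)OCCC(C)C)cc1F` is the reference point here. Within the data shown here, in an assay on isolated protein for binding affinity to Type-2 angiotensin II receptor (Homo sapiens) (a higher number here means a weaker inhibitor, a lower number a stronger inhibitor), compound 2 gives 1 nM, the lowest of the three numbers measured so far. Compound 1 `CCCc1nc(CC)c(C(=O)OCc2ccccc2S(=O)(=O)c2ccccc2)n1Cc1ccc(-c2ccccc2S(=O)(=O)NC(=O)OCCC(C)C)cc1F` gives 5 nM, and compound 3 `CCCc1nc(CC)c(C(=O)OCc2ccccc2OCCC(C)C)n1Cc1ccc(-c2ccccc2S(=O)(=O)NC(=O)OCCC(C)C)cc1F` gives 10 nM. Each of the measured steps swaps a group on an aromatic carbon: a 5.0-fold lower number from compound 1 to compound 2 (0.70 log units; beyond the scatter), a 2.0-fold higher number from compound 1 to compound 3 (0.30 log units; within the scatter), and a 10-fold higher number from compound 2 to compound 3 (1.00 log units; beyond the scatter). Compound 4 `CCCc1nc(CC)c(C(=O)NCCCOc2ccccc2)n1Cc1ccc(-c2ccccc2S(=O)(=O)NC(=O)OCCC(C)C)cc1F` alters a different part of the molecule: (3-phenoxypropyl)amino in place of (2-methoxybenzyl)oxy on a carbonyl carbon. The ester linkage thereby becomes an amide, and the entering group brings one hydrogen-bond donor where the leaving group had none. Among the measured compounds shown here, no measured step changes this part of the structure, so nothing in the data speaks directly to it; the measured steps show only that this region of compound 2 accepts changes with modest shifts in this assay. A higher number is expected, a 10-fold higher number from compound 2 to compound 4 (1.00 log units; beyond the scatter), since every departure from compound 2 so far has raised the number, as in a 10-fold higher number from compound 2 to compound 3 (1.00 log units; beyond the scatter). Compound 4 is therefore estimated at 10 nM, with a likely range from 2 nM to 60 nM.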

Compound 4, half-maximal inhibitory concentration: 9 nM
The estimate for compound 4 lay 1.1-fold (0.05 log units) above the measured number; low and high end bracket the measured number.
By their numbers in this assay, from the lowest: compound 2; then compounds 1, 4 and 3 (each within the scatter of the next).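

In this assay, among these compounds, the swap of (2-methoxybenzyl)oxy for (3-phenoxypropyl)amino on the carbonyl carbon gives a 9.0-fold higher number from compound 2 to compound 4 (0.95 log units; beyond the scatter), so this position, untouched by the earlier steps, does respond to change, and the step lies beyond the scatter. The step bundles several differences: the ester becomes an amide, the entering group brings a hydrogen-bond donor, and the chain leading to the aromatic ring is different, so this single result cannot be credited to any one of them, although one six-membered aromatic ring is present on both sides. No measurement available here accounts for the rise in the number.

The compounds shown leave open whether the amide linkage or the chain matters more, a question that (2-methoxybenzyl)amino on the same carbonyl carbon would address by changing the linkage alone. They also leave open how a shorter chain, as in (2-phenoxyethyl)amino, or a free carboxylic acid at this carbonyl would compare with compound 2.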